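Ring in place of an open chain end: compound 3

The compounds below may be only part of what the source reports. "The series", "measured", "known", "first", "only" and "open" are said of these compounds alone.

For the measured compounds named here, in a functional assay on A549 cells (Homo sapiens) for antiproliferative activity (a higher number here means a weaker inhibitor of growth, a lower number a stronger inhibitor of growth), compound 1 `CC/C=C\[C@H](C)[C@H](OC(N)=O)[C@@H](C)[C@H](O)[C@@H](C)C/C(C)=C\[C@H](C)[C@@H](O)[C@@H](C)/C=C\[C@@H](O)C[C@H](O)[C@H](C)CO` gives 3000 nM and compound 2 `CC/C=C\[C@H](C)[C@H](OC(N)=O)[C@@H](C)[C@H](O)[C@@H](C)C/C(C)=C\[C@H](C)[C@@H](O)[C@@H](C)/C=C\[C@@H](O)C[C@H](O)[C@H](C)C[C@H](C)C(=O)OC` gives 4000 nM, so compound 2 stands within the scatter of the only other measured compound. Compound 3 `CC/C=C\[C@H](C)[C@H](OC(N)=O)[C@@H](C)[C@H](O)[C@@H](C)C/C(C)=C\[C@H](C)[C@@H](O)[C@@H](C)/C=C\[C@@H](O)C[C@@H]1OC(=O)[C@H](C)[C@@H](O)[C@H]1C` differs from compound 2 by a group of 10 heavy atoms (7 carbon, 3 oxygen; one six-membered non-aromatic ring with 1 hetero atom) in place of a group of 11 heavy atoms (8 carbon, 3 oxygen; no ring), on a saturated chain carbon, two bonds along the chain from a double-bonded chain carbon and an oxygen on a saturated carbon. This places a six-membered non-aromatic ring on a saturated chain carbon, two bonds along the chain from a double-bonded chain carbon and an oxygen on a saturated carbon. Going by the values given here, the only measured step, a 1.3-fold higher number from compound 1 to compound 2 (0.12 log units; within the scatter), stays within the scatter, but it joins two open-chain compounds and offers no direct guide to a ring. Among the compounds with values here, no measured compound carries this ring, so the direction is a judgement with a wide margin. In this assay the expected change is a 40-fold lower number from compound 2 to compound 3 (1.60 log units; beyond the scatter), beyond the scatter and toward stronger growth inhibition. Compound 3 is estimated at 100 nM, with an expected range of 20 nM to 600 nM.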

Compound 3, concentration for 50% growth inhibition: 7 nM
The estimate for compound 3 lay 14-fold (1.15 log units) above the measured number; the whole stated range lies above it.
By their numbers in this assay, from the lowest: compound 3; then compounds 1 and 2 (each within the scatter of the next).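

In this assay, placing the six-membered non-aromatic ring with 1 hetero atom on this saturated chain carbon gives a 570-fold lower number from compound 2 to compound 3 (2.76 log units; beyond the scatter), and measured against the shorter open-chain group it gives a 430-fold lower number from compound 1 to compound 3 (2.63 log units; beyond the scatter), both large. The two open-chain groups of compound 1 and compound 2 stand within the scatter of each other, so this position had appeared insensitive to the change at the chain end; the ring shows that the number here can move far toward stronger growth inhibition. No evidence at hand bears on the size of these steps.

The compounds shown do not separate the ring itself from the groups it carries. On these data alone, how a five-membered non-aromatic ring, or an open chain ending in a carboxylic acid, would stand in this assay also remains open.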